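Three Close Values and an Unmeasured Butoxy Analogue

A few compounds are considered here, and "the series" means these few. Any claim that something is new, unique, unknown or untested is made for them only; others in the source may bear on it.

Measured in a functional assay on COLO 205 cells (Homo sapiens) for cytotoxicity; on this read-out higher numbers stand for weaker inhibition and lower numbers for stronger inhibition
- Compound 1 (`O=S(=O)(N/C(=N\O)Nc1ccc(Cl)cc1)c1ccccc1`) gives 53 ug/mL
- Compound 2 (`O=S(=O)(N/C(=N\O)Nc1ccc(Cl)cc1)c1cc(C(F)(F)F)cc(C(F)(F)F)c1`) gives 58 ug/mL
- Compound 3 (`Cc1c(S(=O)(=O)N/C(=N\O)Nc2ccc(Cl)cc2)sc2ccc(Cl)cc12`) gives 60 ug/mL

Compound 1 stands level with the other two, its number lying within the scatter of both compound 2 and compound 3. Compound 4 (`CCCCOc1ccc(S(=O)(=O)N/C(=N\O)Nc2ccc(Cl)cc2)cc1`) remains unmeasured. Relative to compound 1, it has butoxy in place of hydrogen on an aromatic carbon, para to a large group (butoxy in place of hydrogen on an aromatic carbon). Going by the values given here, no two measured compounds differ in one place only. Compound 2 at 58 ug/mL and compound 3 at 60 ug/mL carry other groups on the sulfonyl side than compound 1 at 53 ug/mL yet stay within the scatter, so no step beyond the scatter is expected in this assay for this change. The estimated step (a 1.1-fold lower number from compound 1 to compound 4 (0.04 log units; within the scatter)) is accordingly small. Compound 4 is estimated at 48 ug/mL with 22 ug/mL to 85 ug/mL as the expected range.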

Compound 4, half-maximal inhibitory concentration: 49 ug/mL
Compound 4: the middle estimate sits 1.0-fold (0.01 log units) below what was measured, within the range that was stated.
By their numbers in this assay, from the lowest: compounds 4, 1, 2 and 3 (each within the scatter of the next).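

Going by these compounds alone, compounds 1 and 4 form the only pair here that differs in one place, so this change can now be read on its own. In this assay, butoxy in place of hydrogen on an aromatic carbon, para to a large group, gives a 1.1-fold lower number from compound 1 to compound 4 (0.03 log units; within the scatter) and so adds no step beyond the scatter at this position. Nothing measured here bears on this result.

As far as these compounds go, whether an amine, a carboxylic acid or a methoxy group at this position would also stay within the scatter remains open.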